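From Chloro to Benzyloxy on a Shared Core

A few compounds are considered here, and "the series" means these few. Any claim that something is new, unique, unknown or untested is made for them only; others in the source may bear on it.

Compound 1 `CC(=O)N1N=C(c2ccc3ccccc3c2)OC1c1ccc(Br)cc1`: 2.08 ug/mL
Compound 2 `CC(=O)N1N=C(c2ccc3ccccc3c2)OC1c1ccc(Cl)cc1`: 1.88 ug/mL

Both compounds were tested in a functional assay on HepG2 cells (Homo sapiens) for antiproliferative activity, read by MTT assay, with a stated time of 48 h; a higher number here means a weaker inhibitor, a lower number a stronger inhibitor. On these numbers, compound 2 at 1.88 ug/mL stands level with compound 1 at 2.08 ug/mL, within the scatter of the measurement.

The next structure is compound 3 `CC(=O)N1N=C(c2ccc3ccccc3c2)OC1c1ccc(OCc2ccccc2)cc1`, which keeps the core of compound 2 and carries benzyloxy in place of chloro on an aromatic carbon, para to a large group: benzyloxy in place of chloro on an aromatic carbon.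

Within the data shown here, only one measured step bears on this change: a 1.1-fold lower number from compound 1 to compound 2 (0.04 log units; within the scatter), with chloro in place of bromo on an aromatic carbon. That step stays within the scatter, but it offers limited guidance, since neither measured compound carries a benzyloxy group. Among the measured compounds shown here, the data therefore support no firm direction, and no step clearly beyond the scatter is expected, although the uncertainty is wide. The expected step is a 1.3-fold higher number from compound 2 to compound 3 (0.11 log units; within the scatter). For compound 3 the estimate is 2.4 ug/mL, with an expected range from 0.8 ug/mL to 7.5 ug/mL.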

Compound 3, half-maximal inhibitory concentration: 3.38 ug/mL
Compound 3: the middle estimate sits 1.4-fold (0.15 log units) below what was measured; low and high end bracket the measured number.
By their numbers in this assay, from the lowest: compounds 2, 1 and 3 (each within the scatter of the next).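

The earlier compounds shown here only exchanged one halogen for another at this position, on an aromatic carbon para to a large group, so they showed nothing about a substituent of a different size. Benzyloxy, with 8 heavy atoms and a six-membered aromatic ring of its own, now stands where chloro had a single heavy atom, and this assay records a 1.8-fold higher number from compound 2 to compound 3 (0.25 log units; within the scatter) for that exchange. Measured against the bromo compound, the same position gives a 1.6-fold higher number from compound 1 to compound 3 (0.21 log units; within the scatter), so in this series a far larger group, carrying an oxygen, leaves the number within the scatter of both halogen compounds, and no information on the reason for this is available here.

The three compounds do not settle whether any other group at this position would produce a step beyond the scatter, for example a methoxy, an amine or a carboxylic acid. They also leave open whether a hydroxyl or a longer chain ending in a phenyl ring would behave like benzyloxy, and whether the result would hold on a different core.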